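The source may report more compounds than this note shows. Statements on the series, on what has been measured and on what is new or still open speak of the compounds shown alone.

Compound 1 `CC(=O)Oc1cc(OC(C)=O)c2c(OC(C)=O)cc(C)c(Cl)c2c1OC(C)=O` gives 52900 nM
Compound 2 `COc1c(C)cc(Cl)c2c1C(=O)C=CC2=O` gives 41500 nM
Compound 3 `CC(=O)Oc1cc(C)c(Cl)c2c1C(=O)C=CC2=O` gives 26200 nM

These values come from a functional assay on HeLa cells (Homo sapiens) for cytotoxicity, read by XTT assay, with a stated time of 24 h; a lower number here means a stronger inhibitor, a higher number a weaker inhibitor. Compound 3, at 26200 nM, lies within the scatter of compound 2, while compound 1 has a higher number, beyond the scatter from compound 3. Compound 4 `COc1cc(C)c(Cl)c2c1C(=O)C=CC2=O` carries methyl in place of acetyl on an oxygen on an aromatic ring. For the measured compounds named here, no pair of measured compounds shows this change on its own. Going by the values given here, the only guide is compound 2, which also carries methoxy and gives 41500 nM. A small rise in the number, within the scatter, is therefore expected. The expected change is a 1.3-fold higher number from compound 3 to compound 4 (0.11 log units; within the scatter). For compound 4 the estimated value is 34000 nM, with an expected range from 17000 nM to 65000 nM.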

Compound 4, half-maximal inhibitory concentration: 19100 nM
For compound 4 the middle estimate is 1.8-fold (0.25 log units) above the measured one; low and high end bracket the measured number.
By their numbers in this assay, from the lowest: compounds 4, 3, 2 and 1 (each within the scatter of the next, the first and the last beyond it).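

In this assay the change from acetoxy to methoxy on an oxygen on an aromatic ring gives a 1.4-fold lower number from compound 3 to compound 4 (0.14 log units; within the scatter) and offers the first direct reading of this change among the compounds shown. At this place, exchanging acetyl for methyl, and so losing its double bond and hydrogen-bond acceptor, moves the number only within the scatter. The data shown offer no measured explanation for this result. From the compounds shown here alone, whether a free hydroxyl, a longer chain such as ethoxy, or an amine in this place would move the number beyond the scatter remains open.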